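This account rests on a few compounds, and the source may have more. Where it says the series, first, only, none or still open, it means among the compounds named here.

Compound 3 `O=C(Oc1ccc(-c2ccc(F)cc2F)cc1C(=O)Nc1ccccc1)c1ccccc1` stands second highest of three numbers in a functional assay on the whole organism (Ear) for inhibition, with Mus musculus as the target, at a dose of 40 mg/kg by the oral route (a higher number here means more inhibition at the dose given (going by the name of the read-out), a lower number less inhibition), where compound 3 gives 19.8%. Compound 2 `CC(=O)Oc1ccc(-c2ccc(F)cc2F)cc1C(=O)Nc1ccccc1` gives 23.2% and compound 1 `O=C(Oc1ccc(-c2ccc(F)cc2F)cc1C(=O)O)c1ccccc1` gives 16.1%, and both gaps to compound 3 lie within the scatter. Compound 4 `CCN(CC)C(=O)c1cc(-c2ccc(F)cc2F)ccc1OC(=O)c1ccccc1` differs from compound 3 in one place: diethylamino in place of anilino on a carbonyl carbon. The measured step that bears most on this change is a number 3.7 percentage points higher from compound 1 to compound 3 (within the scatter), since it also alters the group on that carbonyl carbon; the other step, a number 3.4 percentage points lower from compound 2 to compound 3 (within the scatter), concerns a different group. Neither step goes beyond the scatter, so no step beyond the scatter is expected for compound 4 either. Compound 4 is therefore estimated at 20%, between 8% and 32%. The expected step is a number 0.2 percentage points higher from compound 3 to compound 4 (within the scatter).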

Compound 4, a percentage reported as inhibition, in the whole organism at one dose (the size of the read-out at that dose, not a potency): 65.2%
For compound 4 the middle estimate is 45.2 percentage points below the measured one; the measured number lies above the stated range.
By their numbers in this assay, from the lowest: compounds 1, 3 and 2 (each within the scatter of the next); then compound 4.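

In this assay, the group on this carbonyl carbon turns out to matter a great deal: diethylamino in place of anilino gives a number 45.4 percentage points higher from compound 3 to compound 4 (beyond the scatter), and diethylamino in place of hydroxy gives a number 49.1 percentage points higher from compound 1 to compound 4 (beyond the scatter). Anilino in place of hydroxy gave only a number 3.7 percentage points higher from compound 1 to compound 3 (within the scatter), so at this position replacing hydroxy raises the number with diethylamino but not with anilino. Nothing available explains this difference between the two groups. As far as these compounds go, it remains open whether dimethylamino, dipropylamino or piperidine on this carbonyl carbon would hold the number, and whether diethylamino would give a similar step with the acetyl ester of compound 2.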